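Swapping the sulfonyl aryl ring of compound 1 for a dimethylphenyl

The compounds below may be only part of what the source reports. "The series", "measured", "known", "first", "only" and "open" are said of these compounds alone.

Compound 1 `COc1ccc(-c2c(S(=O)(=O)c3cccc(F)c3)cnc3cc(F)ccc23)cc1` has the highest number of the three compounds measured in an ADME assay on microsomes from liver (Homo sapiens) for metabolic stability, tested at 2.5 uM (on this read-out higher numbers stand for fast clearance and lower numbers for slow clearance), where compound 1 gives 1.89 mL/min. Compound 3 `O=S(=O)(c1cccc(F)c1)c1cnc2cc(F)ccc2c1-c1ccc(Cl)cc1` is nearest, with 0.98 mL/min in this assay, and the step of a 1.9-fold lower number from compound 1 to compound 3 (0.29 log units; within the scatter) is within the scatter. Compound 2 `O=S(=O)(c1ccc(F)c(F)c1)c1cnc2cc(F)ccc2c1-c1ccc(Cl)cc1` stands furthest away, at 0.01 mL/min in this assay; the step of a 98-fold higher number from compound 2 to compound 3 (1.99 log units; beyond the scatter) shows that a single change on the sulfonyl aryl ring can move the number by a large amount.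

Compound 4 `COc1ccc(-c2c(S(=O)(=O)c3ccc(C)c(C)c3)cnc3cc(F)ccc23)cc1` differs from compound 1 in one place: 3,4-dimethylphenyl in place of 3-fluorophenyl on a sulfonyl sulfur.

Within the data shown here, no measured step mirrors this particular change. The step from compound 1 to compound 3 concerns the other aryl ring and is within the scatter, while the step from compound 2 to compound 3 touches the sulfonyl aryl ring but exchanges a different pair of groups. The measured data therefore give no direct guide, only the observation that the sulfonyl aryl ring is a place where the number has shifted strongly. Compound 1 already sits at the fast-clearance end, so the author expects compound 4 to stay near it or move somewhat higher, with the step of a 1.3-fold higher number from compound 1 to compound 4 (0.12 log units; within the scatter) estimated to be modest. In this assay compound 4 is expected to give about 2.5 mL/min, in the range 1 mL/min to 6 mL/min.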

Compound 4, intrinsic clearance in a liver preparation (reported as CLH), per the amount of preparation that the assay uses: 4.13 mL/min
For compound 4 the middle estimate is 1.7-fold (0.22 log units) below the measured one; the measured number falls inside the stated range.
By their numbers in this assay, from the lowest: compound 2; then compounds 3 and 1 (each within the scatter of the next); then compound 4.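

Exchanging 3-fluorophenyl for 3,4-dimethylphenyl on a sulfonyl sulfur gives a 2.2-fold higher number from compound 1 to compound 4 (0.34 log units; beyond the scatter) in this assay and leaves compound 4 with the highest number of the four, showing that compound 1 did not mark the upper end for this series and that a change at this position can lift the number further even from there. The one earlier step on the sulfonyl aryl ring, a 98-fold higher number from compound 2 to compound 3 (1.99 log units; beyond the scatter), was also upward but much larger, and it was seen with a chloro group on the other aryl ring, whereas the new step is modest and was seen with the methoxy group in place, so movement at this ring is now shown with both groups, though not for the same exchange. No measured information on the compounds shown accounts for the rise.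

The change removes the fluorine and adds two methyl groups at once, so the compounds shown leave open whether one of these alterations alone would carry the step, and whether the same exchange would move the number similarly with the chloro group in place of the methoxy group. They also leave open how the number would respond to a sulfonyl aryl ring bearing an amine or a carboxylic acid, or to a longer alkyl chain on that ring.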